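A Carbamate in Place of an Acetyl Group

This account rests on a few compounds, and the source may have more. Where it says the series, first, only, none or still open, it means among the compounds named here.

Measured so far:
compound 1, `CC(=O)N1CCN(CCN2CCC(CNC(=O)c3cccc4[nH]c(C(C)C)nc34)CC2)CC1`: 39800 nM
compound 2, `CS(=O)(=O)N1CCN(CC(O)CN2CCC(CNC(=O)c3cccc4[nH]cnc34)CC2)CC1`: 50100 nM

Both compounds bind only weakly. In an assay on isolated protein for binding affinity to 5-hydroxytryptamine receptor 3A (Homo sapiens) (a lower number here means a stronger inhibitor, a higher number a weaker inhibitor), compound 1 gives 39800 nM, and compound 2 gives 50100 nM. Compound 1 has the lower of the two numbers, yet the two values lie within the usual scatter of each other, so nothing separates them.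

Compound 3, `COC(=O)N1CCN(CCN2CCC(CNC(=O)c3cccc4[nH]c(C(C)C)nc34)CC2)CC1`, has not been measured. It differs from compound 1 in one place: methoxy in place of methyl on a carbonyl carbon. Among the measured compounds shown here, no pair of measured compounds differing in a single place is available, so there is no measured step to lean on. Given that compound 1 is already weak at 39800 nM and the change is small, the expected step is a 1.0-fold higher number from compound 1 to compound 3 (0.00 log units; within the scatter), no larger than the scatter, in no particular direction. Compound 3 is therefore estimated at 40000 nM, with a range from 15000 nM to 110000 nM.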

Compound 3, inhibition constant: 79400 nM
Beside the measured number, compound 3's estimate is 2.0-fold (0.30 log units) below it; the measured number falls inside the stated range.
By their numbers in this assay, from the lowest: compounds 1, 2 and 3 (each within the scatter of the next).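

Among the compounds shown here, this is the first comparison that differs in only one place. In this assay, going from 4-acetylpiperazin-1-yl to 4-(methoxycarbonyl)piperazin-1-yl gives a 2.0-fold higher number from compound 1 to compound 3 (0.30 log units; within the scatter), so methoxy in place of methyl on this carbonyl carbon, with one more heavy atom and one more hydrogen-bond acceptor, causes no change that can be told from the scatter. Nothing measured here accounts for this result.

One small swap at one position says little about how much this carbonyl carbon can tolerate, and all the compounds shown remain weak binders. Going by these compounds, whether an amine such as dimethylamino, or a longer chain such as butoxy, on the same carbonyl carbon would move the number beyond the scatter stays open.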